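A few compounds are considered here, and "the series" means these few. Any claim that something is new, unique, unknown or untested is made for them only; others in the source may bear on it.

Measured so far in an assay on HEK293 cells for displacement of a labelled ligand from Melanocortin receptor 4 (Homo sapiens); on this read-out lower numbers stand for stronger inhibition and higher numbers for weaker inhibition:
- compound 1 `CC(C)[C@H](NC(=O)CCN(C)C)c1cccc(F)c1N1CCN(C(=O)[C@@H]2CN(C(C)C)C[C@H]2c2cccc(Cl)c2)CC1`: 370 nM
- compound 2 `Cc1ccc(N2CCN(C(=O)[C@@H]3CNC[C@H]3c3ccc(Cl)cc3)CC2)c([C@@H](NC(=O)CCN(C)C)C(C)C)c1`: 7.2 nM
- compound 3 `Cc1ccc(N2CCN(C(=O)[C@@H]3CN(C4CCOCC4)C[C@H]3c3ccc(Cl)cc3)CC2)c([C@@H](NC(=O)CN)C(C)C)c1`: 2 nM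

Compound 2 stands second highest of the three numbers in this assay. Compound 3 gives the lowest number, with compound 2 nearer to it than to compound 1, which gives the highest number of the set; the gap from compound 2 to compound 1 is the widest in the series. Compound 1 and compound 3 each differ from compound 2 in more than one place, so neither gives a single-change step that could be read directly.

Compound 4 `CCC(=O)N1C[C@@H](C(=O)N2CCN(c3ccc(C)cc3[C@@H](NC(=O)CCN(C)C)C(C)C)CC2)[C@H](c2ccc(Cl)cc2)C1` is the one-step change from compound 2: propanoyl in place of hydrogen on an amine nitrogen in a ring. Among the measured compounds the amine nitrogen in a ring carries either hydrogen or a carbon substituent; an acyl group on that nitrogen has not been measured here, so the direction of the step is uncertain. The expectation for compound 4 is a moderate weakening, a step from compound 2 to compound 4 of a 2.8-fold higher number from compound 2 to compound 4 (0.44 log units; beyond the scatter), estimated as 20 nM with a range from 5 nM to 80 nM.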

Compound 4, inhibition constant: 4.6 nM
Compound 4: middle estimate off by 4.3-fold (0.64 log units), on the high side, outside the stated range (below it).
By their numbers in this assay, from the lowest: compound 3; then compounds 4 and 2 (each within the scatter of the next); then compound 1.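

In this assay the step of a 1.6-fold lower number from compound 2 to compound 4 (0.19 log units; within the scatter) shows that an acyl group on this amine nitrogen in a ring, the first seen in the series, can be carried with no readable difference from the free amine nitrogen of compound 2. The position therefore accepts propanoyl, with its carbonyl and its 4 heavy atoms, and the number stays within the usual scatter. Nothing on hand accounts for this result.

On these data alone, whether a longer acyl chain such as butanoyl, or a sulfonyl or urea group on this nitrogen, would behave like propanoyl remains open. Compound 1 and compound 3 carry carbon substituents on this nitrogen but also differ from compound 2 elsewhere, so acyl against alkyl on this nitrogen cannot be read from them.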